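The compounds below may be only part of what the source reports. "The series", "measured", "known", "first", "only" and "open" are said of these compounds alone.

Measured in a functional assay on HCT-116 cells (Homo sapiens), read by MTT assay, with a stated time of 72 h; a higher number here means a weaker inhibitor, a lower number a stronger inhibitor:
- compound 1 `Nc1nc(N)c2c(-c3cccs3)cn([C@@H]3O[C@H](CO)[C@@H](O)[C@H]3O)c2n1`: > 20000 nM, a limit
- compound 2 `Cc1nc(N)c2c(-c3cccs3)cn([C@@H]3O[C@H](CO)[C@@H](O)[C@H]3O)c2n1`: > 20000 nM, a limit

Compound 2 has no numerical value, only the limit > 20000 nM. Compound 3 `Cc1nc(N)c2c(I)cn([C@@H]3O[C@H](CO)[C@@H](O)[C@H]3O)c2n1` carries iodo in place of thiophen-2-yl on an aromatic carbon of the shared core: iodo in place of thiophen-2-yl on an aromatic carbon.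

For the measured compounds named here, the one measured step, a step that the two limits leave unreadable from compound 1 to compound 2, concerns a different change and gives no size to carry over. Going by the values given here, no measured step involves thiophen-2-yl or iodo. Among the compounds with values here, the only other guide is the limit of > 20000 nM in this assay, at which 2 of the 2 values shown sit. On that basis, little movement is expected in this assay, and a value near the limit is likely, with a modest gain in potency as the more open direction.

Estimated step: an at least 1.3-fold lower number from compound 2 to compound 3 (0.12 log units; that floor lies within the scatter). The expected value for compound 3 is 15000 nM, with an estimated range of 3000 nM to 30000 nM.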

Compound 3, half-maximal inhibitory concentration: > 20000 nM
Compound 3 was reported as a limit (the forecaster's own chance of this, stated with the estimate: 65%); middle value at least 1.3-fold (0.12 log units) from the limit.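

In this assay, for the compounds shown here, compound 3 gives > 20000 nM, a limit, so no step from compound 2 to compound 3 can be read. Going by these compounds alone, the series so far shows one result: the limit of > 20000 nM in this assay, at which 3 of the 3 values shown sit. The compounds shown leave open which change to the shared core, if any, gives a numerical value in this assay.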